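The source may hold more compounds than are shown below. What is called first, only, known or untested is meant among the compounds shown, and "the series" means these compounds.

Compound 1 `Cn1ccc2c(Oc3ccc(NC(=O)c4cn(-c5ccc(Cl)cc5)c5ccccc5c4=O)cc3F)ccnc21` gives 290 nM in a functional assay on HepG2 cells (Homo sapiens) for inhibition, read by MTT assay, with a stated time of 72 h; on this read-out higher numbers stand for weaker inhibition and lower numbers for stronger inhibition.
Compound 2 `Cn1ccc2c(Oc3ccc(NC(=O)c4cn(-c5ccc(Br)cc5)c5ccccc5c4=O)cc3F)ccnc21` gives 1260 nM in this assay.
Compound 3 `Cn1ccc2c(Oc3ccc(NC(=O)c4cn(-c5ccc(F)c(Cl)c5)c5ccccc5c4=O)cc3F)ccnc21` gives "not determined" (no result reported) in this assay, so no number is available for it.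

In this assay compound 1 gives 290 nM, the lowest of the two numbers reported. Compound 2 gives 1260 nM, the step being a 4.3-fold higher number from compound 1 to compound 2 (0.64 log units; beyond the scatter). Compound 4 `O=C(Nc1ccc(Oc2ccnc3[nH]ccc23)c(F)c1)c1cn(-c2ccc(Cl)cc2)c2ccccc2c1=O` differs from compound 1 by hydrogen in place of methyl on an aromatic nitrogen. Among the measured compounds shown here, none of the measured steps bears on this change: the only step, a 4.3-fold higher number from compound 1 to compound 2 (0.64 log units; beyond the scatter), concerns a halogen exchange and not the aromatic nitrogen. With nothing in the data speaking for a shift in either direction, compound 4 is expected to stay close to compound 1 in this assay. The expected step is a 1.4-fold higher number from compound 1 to compound 4 (0.14 log units; within the scatter), within the scatter. The estimate for compound 4 is 400 nM, with a range from 150 nM to 1200 nM.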

Compound 4, half-maximal inhibitory concentration: 380 nM
Compound 4: the middle estimate sits 1.1-fold (0.02 log units) above what was measured; the measured number falls inside the stated range.
By their numbers in this assay, from the lowest: compounds 1 and 4 (each within the scatter of the next); then compound 2.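

In this assay, hydrogen in place of methyl on the aromatic nitrogen gives a 1.3-fold higher number from compound 1 to compound 4 (0.12 log units; within the scatter), so this exchange does not separate the two compounds on this read-out. The earlier step spoke only to the halogen, and this one shows that the methyl on this nitrogen is not needed to keep the number of compound 1. Nothing at hand explains this result.

Going by these compounds, whether an ethyl or a 2-hydroxyethyl chain on this nitrogen would leave the number unchanged remains open. So does whether bromo in place of chloro would have the same effect with hydrogen on this nitrogen.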